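This account rests on a few compounds, and the source may have more. Where it says the series, first, only, none or still open, it means among the compounds named here.

Measured in a functional assay on A549 cells (Homo sapiens) for antiproliferative activity, read by MTT assay, with a stated time of 48 h; a higher number here means a weaker inhibitor, a lower number a stronger inhibitor:
- compound 1 `O=C(OCc1ccccc1)c1ccc2[nH]c(-c3cn(-c4ccccc4)nc3-c3ccc(F)cc3)nc2c1`: 21500 nM
- compound 2 `Cc1ccc2[nH]c(-c3cn(-c4ccccc4)nc3-c3ccc(Cl)cc3)nc2c1`: 4640 nM

Of these two measured compounds, compound 2 has the lower number, at 4640 nM. It is therefore the stronger inhibitor of the pair, and the gap to compound 1 lies beyond the usual scatter of repeated measurements.

The next structure is compound 3 `O=C(OCc1ccccc1)c1ccc2[nH]c(-c3cn(-c4ccccc4)nc3-c3ccc(Cl)cc3)nc2c1`. Compared with compound 2, it has benzyloxycarbonyl in place of methyl on an aromatic carbon. For the measured compounds named here, no pair of measured compounds shows this change on its own, so any prediction for it remains uncertain.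

The best available guide is compound 1, which also carries benzyloxycarbonyl and gives 21500 nM. On that basis, a move to a higher number in this assay, meaning weaker inhibition, is expected, with a size beyond the scatter. The estimated change is a 3.0-fold higher number from compound 2 to compound 3 (0.48 log units; beyond the scatter). For compound 3, the expected value is 14000 nM, with an estimated range from 5000 nM to 35000 nM.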

Compound 3, half-maximal inhibitory concentration: 7730 nM
Compound 3: the middle estimate sits 1.8-fold (0.26 log units) above what was measured, and the stated range covers the measured number.
By their numbers in this assay, from the lowest: compounds 2 and 3 (each within the scatter of the next); then compound 1.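

In this assay, the step for benzyloxycarbonyl in place of methyl on this aromatic carbon is a 1.7-fold higher number from compound 2 to compound 3 (0.22 log units; within the scatter), so this much larger group, which brings a ring of its own, leaves the number within the scatter of the methyl compound. Compound 1 and compound 2 differ in two places and could not separate the two changes, whereas chloro in place of fluoro on an aromatic carbon, with benzyloxycarbonyl kept, now stands alone as a 2.8-fold lower number from compound 1 to compound 3 (0.44 log units; beyond the scatter), a modest step beyond the scatter, so among these three compounds only the halogen swap gives a step beyond the scatter. Nothing in the available data explains either step.

From the compounds shown here alone, whether a carboxylic acid, a primary amide or an aminomethyl group on this aromatic carbon would fall in the same range as methyl and benzyloxycarbonyl remains open. Going by these compounds, the halogen comparison also rests on a single pair, so it is unknown whether chloro in place of fluoro gives a similar step with methyl at this position, or how a methoxy group in place of the halogen would compare.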